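The source may report more compounds than this note shows. Statements on the series, on what has been measured and on what is new or still open speak of the compounds shown alone.

Of the compounds shown here, three have been tested so far for their toxicity to cells. In an ADME assay on cells (Bos taurus) for cytotoxicity (on this read-out higher numbers stand for lower toxicity in this test and lower numbers for higher toxicity in this test), compound 1 `Nc1nc(O)c2ncn([C@H]3C[C@H](OC4Sc5ccccc5S4)[C@@H](CO)O3)c2n1` gives > 100000 nM, which is a limit of the assay and not a number. Compound 2 `CSc1ccccc1SCO[C@H]1C[C@H](n2cc(C)c(=O)[nH]c2=O)O[C@@H]1CO` gives > 100000 nM in this assay, and this too is a limit of the assay. Going by the values given here, compound 3 `O=c1ccn([C@@H]2O[C@H](CO)C(OC3Sc4ccccc4S3)[C@@H]2O)c(=O)[nH]1` gives 73900 nM in this assay, the only actual number among the three results, so it is the only firm reference point for what follows.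

The next compound to be tested, compound 4 `O=c1ccn([C@@H]2O[C@H](CO)C(OC3Sc4ccccc4S3)[C@@H]2OC2Sc3ccccc3S2)c(=O)[nH]1`, differs from compound 3 in one place: a group of 9 heavy atoms (7 carbon, 2 sulfur; one five-membered non-aromatic ring with 2 hetero atoms, one six-membered aromatic ring of carbon only) in place of a hydrogen atom, on an oxygen on a saturated carbon. A hydrogen atom on an oxygen on a saturated carbon gives way to a much larger group. Among the compounds with values here, no pair of measured compounds differs in one place only, so no measured step can guide the size of this one. The expectation therefore starts from compound 3 at 73900 nM. The expected step, a 1.2-fold lower number from compound 3 to compound 4 (0.09 log units; within the scatter), is small, leans slightly toward a lower number and stays within the usual scatter of repeated measurements. The assay may also report only its limit for this compound. For compound 4, the estimated value is 60000 nM, with an expected range from 20000 nM to 100000 nM.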

Compound 4, half-maximal cytotoxic concentration: 48000 nM
Beside the measured number, compound 4's estimate is 1.3-fold (0.10 log units) above it; the range from low to high includes it.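

In this assay, putting the group of 9 heavy atoms in place of a hydrogen atom on this oxygen gives a 1.5-fold lower number from compound 3 to compound 4 (0.19 log units; within the scatter). This is the first step among the compounds shown in which only one place differs, so it is the first direct look at this oxygen on a saturated carbon. Even though compound 3 already carries one copy of this group, adding a second copy on this oxygen produces a step that stays within the usual scatter of repeated measurements, and compound 4 gives an actual number rather than a limit, which cannot be taken for granted in this test: the limit of > 100000 nM in this assay, at which 2 of the 4 values shown sit.

A single step cannot tell whether a much smaller group on this oxygen, such as a methyl or an acetyl group, or an amine in place of the oxygen, would give a similar read-out in this assay. It also leaves open whether the same exchange would give a similar step on the core of compound 1 or the core of compound 2, since neither core has a partner here that differs from it in one place only.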